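A Methyl Group on the Second Phenyl Ring

The source may hold more compounds than are shown below. What is called first, only, known or untested is meant among the compounds shown, and "the series" means these compounds.

Compound 1 `Cn1c(N2N=C(c3ccccc3)CC2c2ccccc2)nc(-c2ccccc2)c(C#N)c1=O`: 35400 nM
Compound 2 `Cn1c(N2N=C(c3ccccc3)CC2c2ccc(Cl)cc2)nc(-c2ccccc2)c(C#N)c1=O`: 3280 nM
Compound 3 `Cn1c(N2N=C(c3ccccc3)CC2c2ccc(F)cc2)nc(-c2ccccc2)c(C#N)c1=O`: 38100 nM

In a functional assay on MCF7 cells (Homo sapiens) for antiproliferative activity, with a stated time of 72 h (a higher number here means a weaker inhibitor, a lower number a stronger inhibitor), compound 3 gives the highest number of the three, though its gap to compound 1 is within the scatter a 1.1-fold higher number from compound 1 to compound 3 (0.03 log units; within the scatter); compound 2 sits far lower a 12-fold higher number from compound 2 to compound 3 (1.07 log units; beyond the scatter). Compound 4 `Cc1ccc(C2=NN(c3nc(-c4ccccc4)c(C#N)c(=O)n3C)C(c3ccc(F)cc3)C2)cc1` differs from compound 3 by methyl in place of hydrogen on an aromatic carbon. Among the measured compounds shown here, none of the measured steps touches this ring: the steps of an 11-fold lower number from compound 1 to compound 2 (1.03 log units; beyond the scatter) and a 12-fold higher number from compound 2 to compound 3 (1.07 log units; beyond the scatter) concern halogens on the other phenyl ring, so they give no direct guide to a methyl here. A step of no more than the scatter is therefore expected, a 1.5-fold lower number from compound 3 to compound 4 (0.18 log units; within the scatter), with a wide range. Compound 4 is estimated at 25000 nM, between 8000 nM and 80000 nM.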

Compound 4, half-maximal inhibitory concentration: 23100 nM
The estimate for compound 4 lay 1.1-fold (0.03 log units) above the measured number; the measured number falls inside the stated range.
By their numbers in this assay, from the lowest: compound 2; then compounds 4, 1 and 3 (each within the scatter of the next).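

Going from phenyl to 4-methylphenyl in this assay gives a 1.6-fold lower number from compound 3 to compound 4 (0.22 log units; within the scatter), so this is the first reading at this ring, and adding one methyl here leaves the number within the scatter. With fluoro on the other phenyl ring, this position therefore shows no clear response to the methyl. No available evidence offers an explanation for this result.

On these data alone, it remains open whether an amine or a methoxy group here would give a step beyond the scatter. As far as these compounds go, it is also open whether the methyl would behave alike with chloro on the other phenyl ring.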